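A few compounds are considered here, and "the series" means these few. Any claim that something is new, unique, unknown or untested is made for them only; others in the source may bear on it.

Working notes on the series. Compound 1 `COc1cc(NC(C)CCCNC(=O)NC(c2ccccc2)c2ccccc2)c2ncccc2c1` and compound 2 `COc1cc(NC(C)CCCNC(=O)NC2CCCCC2)c2ncccc2c1` carry a ring-bearing amine on the carbonyl carbon, compound 3 `CCN(CC)C(=O)NCCCC(C)Nc1cc(OC)cc2cccnc12` a diethylamino group there. In a functional assay on HeLa cells (Homo sapiens), read by MTT assay, with a stated time of 72 h (a higher number here means a weaker inhibitor, a lower number a stronger inhibitor), compound 1 gives 100000 nM. Compound 2 reaches only the limit of this assay, > 100000 nM (the limit of > 100000 nM in this assay, at which 1 of the 3 values shown sits). Compound 3 gives 58000 nM, the lowest of the two numbers, with compound 1 nearest and within the scatter. Among the measured compounds shown here, the one measured step, an at least 1.7-fold lower number from compound 2 to compound 3 (0.23 log units; that floor lies within the scatter), points downward but its floor sits within the scatter. Compound 4 `COc1cc(NC(C)CCCNC(=O)NCC2CCCCC2)c2ncccc2c1` differs from compound 3 by (cyclohexylmethyl)amino in place of diethylamino on a carbonyl carbon. The six-membered ring returns, as in compound 2, so a rise back toward the values of compound 1 and compound 2 is expected, possibly up to a limit. The estimate for compound 4 is 100000 nM, between 40000 nM and 250000 nM, an expected step of a 1.7-fold higher number from compound 3 to compound 4 (0.24 log units; within the scatter).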

Compound 4, half-maximal inhibitory concentration: > 100000 nM
Compound 4: only a limit was reported; the forecaster's own chance of this, stated with the estimate: 40%; the middle value sits exactly at the limit.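

Compound 4 gives only a limit in this assay, > 100000 nM, and not a number. Replacing diethylamino with (cyclohexylmethyl)amino on the carbonyl carbon gives an at least 1.7-fold higher number from compound 3 to compound 4 (0.23 log units; that floor lies within the scatter), so a second cyclohexyl-bearing amine, now with a methyl link to the ring, also yields no number, though this step cannot be told from scatter. The step between compound 2 and compound 4 cannot be read, and the limit now covers more of the series: the limit of > 100000 nM in this assay, at which 2 of the 4 values shown sit.

Still open, from the compounds shown here alone, is how a smaller ring amine such as pyrrolidine, or a longer open-chain amine such as dipropylamino, would read on this carbonyl carbon.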